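The source may report more compounds than this note shows. Statements on the series, on what has been measured and on what is new or still open speak of the compounds shown alone.

Measured so far:
compound 1 `COc1cccc(-c2csc(N/N=C(\C)c3cccnc3)n2)c1` — 3.81 nM in an assay on isolated protein for inhibition of Amine oxidase [flavin-containing] B (Homo sapiens), read by fluorescence; on this read-out lower numbers stand for stronger inhibition and higher numbers for weaker inhibition
compound 2 `COc1cccc(-c2csc(N/N=C(\C)c3cccs3)n2)c1` — 551 nM

For the measured compounds named here, compound 2 has the higher of the two numbers so far, so it is the weaker of the two measured compounds. Going by the values given here, its only neighbour is compound 1, and the one step between them, a 140-fold higher number from compound 1 to compound 2 (2.16 log units; beyond the scatter), is the only measured step in the set; it is far beyond the scatter. Compound 3 `COc1cccc(-c2csc(N/N=C(\C)c3ccco3)n2)c1` has not yet been measured. It differs from compound 2 in a single place: furan-2-yl in place of thiophen-2-yl on a carbon with a double bond to nitrogen. Among the compounds with values here, no measured step shows a furan-2-yl against a thiophen-2-yl, so the step from compound 1 to compound 2 bears on the new change only loosely, as a sign that what stands on the carbon with a double bond to nitrogen matters a great deal. Both groups are five-membered aromatic rings with one hetero atom and one hydrogen-bond acceptor, and nothing in the data argues for a large move in either direction. Compound 3 is therefore expected to stay close to compound 2, with an estimated step of a 1.1-fold higher number from compound 2 to compound 3 (0.04 log units; within the scatter). The estimate for compound 3 is 600 nM, within a range from 150 nM to 2500 nM.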

Compound 3, half-maximal inhibitory concentration: 1680 nM
The estimate for compound 3 lay 2.8-fold (0.45 log units) below the measured number, and the stated range covers the measured number.
By their numbers in this assay, from the lowest: compound 1; then compound 2; then compound 3.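

In this assay, exchanging one five-membered aromatic ring for another on the carbon with a double bond to nitrogen is not a neutral change: furan-2-yl in place of thiophen-2-yl gives a 3.0-fold higher number from compound 2 to compound 3 (0.48 log units; beyond the scatter) even though both groups have the same counts of heavy atoms, hetero atoms and hydrogen-bond acceptors, and oxygen stands where sulfur stood. This position therefore separates two groups that match on all those counts, while the modest size of that step contrasts with a 440-fold higher number from compound 1 to compound 3 (2.64 log units; beyond the scatter) and leaves pyridin-3-yl well ahead of both five-membered rings among the three compounds shown. No measurement offered here explains the order of these groups, so it stands as an observation only.

On these data alone, whether phenyl, pyridin-2-yl or pyridin-4-yl on this carbon would fall closer to pyridin-3-yl or to the five-membered rings stays open. Also open, as far as these compounds go, is what a saturated ring such as piperidine or morpholine would do on the same carbon, and whether the order of the three groups would hold on a core carrying something other than the methoxy group.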